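The source may report more compounds than this note shows. Statements on the series, on what has been measured and on what is new or still open speak of the compounds shown alone.

Measured compounds:
- Compound 1, `Nc1ccccc1NC(=O)c1ccc(CSC(=S)N2CCc3ccccc32)cc1`, in a functional assay on A-375 cells (Homo sapiens) for antiproliferative activity, read by CCK-8 assay, with a stated time of 72 h; a higher number here means a weaker inhibitor, a lower number a stronger inhibitor: 4050 nM
- Compound 2, `Nc1ccccc1NC(=O)c1ccc(CSC(=S)N2CCc3cc(Cl)ccc32)cc1`, in this assay: 5280 nM

Compound 2 has the highest of the two numbers seen so far, though its nearest neighbour is compound 1, and the step of a 1.3-fold higher number from compound 1 to compound 2 (0.12 log units; within the scatter) stays within the usual scatter, so the two compounds cannot be told apart on these data. Compound 3, `COC(=O)c1ccc2c(c1)CCN2C(=S)SCc1ccc(C(=O)Nc2ccccc2N)cc1`, is the next compound to be measured. It differs from compound 2 at a single place: methoxycarbonyl in place of chloro on an aromatic carbon. For the measured compounds named here, the only measured step that touches this position is the one from compound 1 to compound 2, where chloro replaced hydrogen, and that step was small. Going by the values given here, there is no measured example of methoxycarbonyl at this position, so the expectation rests on that single small step. No change beyond the scatter is expected in this assay, and the expected step of a 1.1-fold lower number from compound 2 to compound 3 (0.04 log units; within the scatter) reflects this. Compound 3 is therefore estimated at 4800 nM, with a range from 1600 nM to 14000 nM.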

Compound 3, half-maximal inhibitory concentration: 5880 nM
Estimate against measurement, compound 3: 1.2-fold (0.09 log units) below; the range from low to high includes it.
By their numbers in this assay, from the lowest: compounds 1, 2 and 3 (each within the scatter of the next).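

In this assay, this position on the shared core accepts far more than a single atom: the swap of chloro for methoxycarbonyl, a group of four heavy atoms with hydrogen-bond acceptors that chloro lacks, gives a 1.1-fold higher number from compound 2 to compound 3 (0.05 log units; within the scatter) and leaves the reading unchanged within the usual spread. Set against plain hydrogen, the same group gives a 1.5-fold higher number from compound 1 to compound 3 (0.16 log units; within the scatter) and again cannot be told apart, so hydrogen, chloro and methoxycarbonyl all read alike at this position. No supporting measurement is available to explain why these three groups read alike.

Still open, going by these compounds, is whether any group here can move the number at all, for example an amine, a carboxylic acid or a longer alkyl chain. On these data alone, it is also open whether changes elsewhere on the shared core would matter more than this position does.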